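A few compounds are considered here, and "the series" means these few. Any claim that something is new, unique, unknown or untested is made for them only; others in the source may bear on it.

Three dichloroacetamides have been measured in a functional assay on KB 3-1 cells (Homo sapiens) for cytotoxicity, read by MTT assay, with a stated time of 68 h; a higher number here means a weaker inhibitor, a lower number a stronger inhibitor. Compound 1 `O=C(Nc1cccc(-c2ccccc2C(F)(F)F)c1)C(Cl)Cl` gives 35900 nM, compound 2 `CCOc1cccc(-c2cc(NC(=O)C(Cl)Cl)cc(-c3cccc(OCC)c3)c2)c1` gives 14800 nM, and compound 3 `O=C(Nc1cccc(-c2ccc(Cl)cc2)c1)C(Cl)Cl` gives 38200 nM. Of the three, compound 3 and compound 1 sit together within the usual scatter of this assay, while compound 2 gives a lower number, at a distance from compound 3 that lies beyond the scatter.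

Compound 4 `O=C(Nc1cccc(-c2ccccc2)c1)C(Cl)Cl` differs from compound 3 in one place: hydrogen in place of chloro on an aromatic carbon. No measured pair among these compounds shares exactly this change, so no measured step is available to guide the expectation. What the numbers do show is that compound 1, whose outer ring carries a trifluoromethyl group instead of the chloro, gives a value close to that of compound 3, which suggests that the substituent on that ring does little here. Compound 4 is therefore expected to land near compound 3, with the step from compound 3 to compound 4 estimated at a 1.2-fold higher number from compound 3 to compound 4 (0.07 log units; within the scatter), within the scatter. The value of compound 4 in this assay is estimated at 45000 nM, with a range from 18000 nM to 110000 nM.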

Compound 4, half-maximal inhibitory concentration: 46800 nM
For compound 4 the middle estimate is 1.0-fold (0.02 log units) below the measured one, within the range that was stated.
By their numbers in this assay, from the lowest: compound 2; then compounds 1, 3 and 4 (each within the scatter of the next).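

In this assay, hydrogen in place of chloro on an aromatic carbon para to a large group gives a 1.2-fold higher number from compound 3 to compound 4 (0.09 log units; within the scatter) and hydrogen in place of trifluoromethyl on an aromatic carbon gives a 1.3-fold higher number from compound 1 to compound 4 (0.12 log units; within the scatter) as the two direct readings against an unsubstituted partner. The earlier compounds shown here had no such partner, and compound 4 now shows that neither chloro in compound 3 nor trifluoromethyl in compound 1 is set apart from hydrogen in this assay.

On these data alone, whether a group of another kind on this ring, such as an amine or a carboxylic acid, would also stay within the scatter remains open, and compound 2 differs from the others in more than one place, so its lower number cannot be traced to a single change. Nothing measured here accounts for these small steps.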